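A few compounds are considered here, and "the series" means these few. Any claim that something is new, unique, unknown or untested is made for them only; others in the source may bear on it.

Three compounds share one core and differ only in the two aryl groups carried on the ether oxygens. In a functional assay on CHO cells for antagonist activity at sphingosine 1-phosphate receptor 2 (Homo sapiens), read by fluorescence (a lower number here means a stronger inhibitor, a higher number a weaker inhibitor), compound 1 `CC(C)CC1(O)CCN(C(=O)Nc2cc(Oc3ccc(F)cc3)cc(Oc3ccc(C4(C(=O)O)CC4)cc3)c2)CC1` gives 6.4 nM, compound 2 `CC(C)CC1(O)CCN(C(=O)Nc2cc(Oc3ccc(C(=O)O)cc3)cc(Oc3ccc(F)c(F)c3)c2)CC1` gives 25 nM, and compound 3 `CC(C)CC1(O)CCN(C(=O)Nc2cc(Oc3ccc(F)cc3)cc(Oc3ccc(C(=O)O)cc3F)c2)CC1` gives 17 nM. Compound 3 therefore stands second highest of the three numbers in this assay. Its nearest neighbour is compound 2, whose number sits within the scatter of it. Going by the values given here, the one step on record, a 2.7-fold higher number from compound 1 to compound 3 (0.42 log units; beyond the scatter), lies beyond the scatter and comes with 4-carboxy-2-fluorophenyl in place of 4-(1-carboxycyclopropyl)phenyl on an oxygen on an aromatic ring.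

Compound 4 `CC(C)CC1(O)CCN(C(=O)Nc2cc(Oc3ccc(F)cc3)cc(Oc3ccc(C(=O)O)cc3)c2)CC1` is not yet measured. It differs from compound 3 by hydrogen in place of fluoro on an aromatic carbon. Among the compounds with values here, no measured step here removes a fluoro from an aromatic carbon, so the step from compound 1 to compound 3 concerns a different change and bears on the question only loosely. With nothing pointing clearly either way, the step from compound 3 to compound 4 in this assay is expected to be small, a 1.1-fold lower number from compound 3 to compound 4 (0.05 log units; within the scatter), and may not rise beyond the scatter. Compound 4 is accordingly estimated to give 15 nM in this assay, with a likely range from 6 nM to 40 nM.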

Compound 4, half-maximal inhibitory concentration: 4 nM
The estimate for compound 4 lay 3.8-fold (0.57 log units) above the measured number, outside the stated range (below it).
By their numbers in this assay, from the lowest: compounds 4 and 1 (each within the scatter of the next); then compounds 3 and 2 (each within the scatter of the next).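

In this assay the fluoro ortho to a large group proves to be no neutral passenger: the change from 4-carboxy-2-fluorophenyl to 4-carboxyphenyl brings a 4.3-fold lower number from compound 3 to compound 4 (0.63 log units; beyond the scatter) and thus a clearly stronger inhibitor. Going by these compounds alone, a fluoro on the other aryl group, the one without the carboxy group, points the same way, since hydrogen in its place gives a 6.3-fold lower number from compound 2 to compound 4 (0.80 log units; beyond the scatter), so in both of these pairs the compound with hydrogen is the stronger inhibitor. The third step, a 1.6-fold lower number from compound 1 to compound 4 (0.20 log units; within the scatter), lies within the scatter, so the plain carboxy group and the 1-carboxycyclopropyl group cannot be told apart in this series, and the gap between compound 1 and compound 3 now tracks the fluoro rather than the cyclopropyl ring.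

Nothing shown here explains why a single fluoro makes this much difference on either ring. As far as these compounds go, it also stays open whether a chloro, methyl or methoxy group ortho to that same large group would weaken inhibition as the fluoro does, or whether only the fluoro has this effect.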